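Removing the trifluoromethyl group from the aryl ring

The source may report more compounds than this note shows. Statements on the series, on what has been measured and on what is new or still open speak of the compounds shown alone.

Measured compounds in an assay on HEK293 cells for displacement of a labelled ligand from Melanocortin receptor 4 (Homo sapiens); a lower number here means a stronger inhibitor, a higher number a weaker inhibitor:
- compound 1 `CC(C)[C@H](NC(=O)CCN(C)C)c1cccc(F)c1N1CCN(C(=O)[C@@H]2CN(C(C)C)C[C@H]2c2ccc(Cl)cc2)CC1`, 5.3 nM
- compound 2 `CC(C)[C@H](NC(=O)CCN(C)C)c1cccc(F)c1N1CCN(C(=O)[C@@H]2CN(C(C)C)C[C@H]2c2cc(F)ccc2F)CC1`, 2050 nM
- compound 3 `CC(C)[C@H](NC(=O)CCN(C)C)c1cccc(F)c1N1CCN(C(=O)[C@@H]2CN(C(C)C)C[C@H]2c2ccc(C(F)(F)F)c(F)c2)CC1`, 51 nM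

All three share one core and differ only in the aryl group on a saturated ring carbon. Compound 3 stands second highest of the three numbers: compound 1 lies nearest, with a 9.6-fold higher number from compound 1 to compound 3 (0.98 log units; beyond the scatter), and compound 2 lies furthest, with a 40-fold lower number from compound 2 to compound 3 (1.60 log units; beyond the scatter). The step of a 390-fold higher number from compound 1 to compound 2 (2.59 log units; beyond the scatter) shows how strongly this aryl group can move the result.

Compound 4 `CC(C)[C@H](NC(=O)CCN(C)C)c1cccc(F)c1N1CCN(C(=O)[C@@H]2CN(C(C)C)C[C@H]2c2cccc(F)c2)CC1` is obtained from compound 3 by the change (hydrogen in place of trifluoromethyl on an aromatic carbon), that is, 3-fluoro-4-(trifluoromethyl)phenyl becomes 3-fluorophenyl. Among the compounds with values here, no measured pair shows this exact change. The two compounds carrying a group at that aromatic position, compound 1 and compound 3, both sit far lower than compound 2, which has none; this suggests, though only from these three, that losing the trifluoromethyl group will weaken binding. For compound 4 the expected step is a 5.9-fold higher number from compound 3 to compound 4 (0.77 log units; beyond the scatter), and the estimated value is 300 nM, within a range of 60 nM to 1500 nM.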

Compound 4, inhibition constant: 560 nM
Estimate against measurement, compound 4: 1.9-fold (0.27 log units) below, and the stated range covers the measured number.
By their numbers in this assay, from the lowest: compound 1; then compound 3; then compound 4; then compound 2.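

Taking away the trifluoromethyl group alone gives an 11-fold higher number from compound 3 to compound 4 (1.04 log units; beyond the scatter), so a group at this ring carbon counts for a large share of the binding on its own; the earlier compounds could not show this, since each of their aryl groups differed in more than one place. Compound 2 and compound 4 both have hydrogen at that carbon, yet replacing a fluoro with hydrogen still gives a 3.7-fold lower number from compound 2 to compound 4 (0.56 log units; beyond the scatter), so the empty position does not settle the result alone. Compound 4 also remains far from the best aryl group, with a 110-fold higher number from compound 1 to compound 4 (2.02 log units; beyond the scatter), which means that the remaining 3-fluorophenyl does not match 4-chlorophenyl.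

Nothing shown here explains why these steps occur. On these data alone, whether methyl, methoxy or nitrile at that same ring carbon would restore binding remains open.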